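The source may hold more compounds than are shown below. What is called first, only, known or untested is meant among the compounds shown, and "the series" means these compounds.

Compound 1, `C[C@@H](Sc1nc2c(cnn2C)c(=O)n1-c1ccccc1)c1ccccc1` — in an assay on isolated protein for inhibition of Retinaldehyde dehydrogenase 3 (Homo sapiens) (on this read-out higher numbers stand for weaker inhibition and lower numbers for stronger inhibition), compound 1 gives 34 nM.
Compound 2, `CC(Sc1nc2c(cnn2C)c(=O)n1-c1ccccc1)c1cccc(F)c1` — in this assay compound 2 gives 128 nM.
Compound 3, `CC(Sc1nc2nn(C3COC3)cc2c(=O)n1-c1ccccc1)c1ccccc1` — in this assay compound 3 gives 109 nM.

Compound 2 carries the highest number of the three, though compound 3 sits within the scatter of it, so the two cannot be ranked against each other. For the measured compounds named here, only one measured step sets compound 2 apart beyond the scatter: a 3.8-fold higher number from compound 1 to compound 2 (0.58 log units; beyond the scatter), a modest loss of inhibition.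

The step now in view leads to compound 4, `CC(Sc1nc2c(cnn2C)c(=O)n1-c1ccccc1)c1cncnc1`. The change is pyrimidin-5-yl in place of 3-fluorophenyl on a saturated chain carbon bound to a saturated chain carbon and a sulfur. Going by the values given here, the only measured step touching this position is the one just mentioned, which swapped a plain phenyl for the fluorinated ring and moved the number by a 3.8-fold higher number from compound 1 to compound 2 (0.58 log units; beyond the scatter). No measured pair trades a carbon-only ring for a ring with nitrogen atoms in it, so the direction of the present step is not anchored by any shown value; the earlier step at the same place gives only a sense that changes here shift the number modestly rather than dramatically.

Compound 4 is therefore expected to land near the number of compound 2, the estimated step being a 1.6-fold higher number from compound 2 to compound 4 (0.19 log units; within the scatter), with the direction genuinely open. The estimate for compound 4 is 200 nM, within a range from 60 nM to 800 nM.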

Compound 4, half-maximal inhibitory concentration: 100 nM
Estimate against measurement, compound 4: 2.0-fold (0.30 log units) above; low and high end bracket the measured number.
By their numbers in this assay, from the lowest: compound 1; then compounds 4, 3 and 2 (each within the scatter of the next).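

Putting pyrimidin-5-yl in place of 3-fluorophenyl gives a 1.3-fold lower number from compound 2 to compound 4 (0.11 log units; within the scatter) in this assay, so these two rings cannot be told apart at this position, even though one has two nitrogen atoms and two hydrogen-bond acceptors and the other has neither. Measured against the plain phenyl ring, the same change gives a 2.9-fold higher number from compound 1 to compound 4 (0.47 log units; beyond the scatter) and joins the earlier fluorine step in showing that both replacement rings give weaker inhibition than the 1-phenylethyl group of compound 1. Nothing available explains why two such different rings give readings this close.

The compounds shown leave open whether a ring with a single nitrogen, such as pyridin-3-yl, or a saturated ring, such as cyclohexyl, would come closer to compound 1 or fall further away. They also leave open whether these ring swaps would have the same effect on the core of compound 3, which differs from the core of compound 1.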